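The source may hold more compounds than are shown below. What is called first, only, known or untested is meant among the compounds shown, and "the series" means these compounds.

Compound 1 `COc1ccccc1Oc1ccc2c(NCCCNCc3ccco3)ccnc2c1` was tested in a physicochemical assay for solubility, with a stated time of 18 h, at pH 7.4 (on this read-out lower numbers stand for lower solubility and higher numbers for higher solubility), where compound 1 gives 14500 nM. Among the compounds with values here, compound 3 `CC(C)(C)c1ccc(Oc2ccc3c(NCCCNCc4ccco4)ccnc3c2)cc1` gives 14500 nM in this assay, and the step of no change at the digits printed from compound 1 to compound 3 (within the scatter) shows that exchanging one aryl group on the ether oxygen for another left the number where it was, so compound 1 and compound 3 together stand highest of the three numbers known. Compound 2 `COc1ccc(F)cc1CNCCCNc1ccnc2cc(CCC(C)C)ccc12` differs from compound 1 in several places at once. In this assay compound 2 gives 4200 nM, a number set apart from that of compound 1 beyond the scatter. Compound 4 `c1coc(CNCCCNc2ccnc3cc(C4CCCCC4)ccc23)c1` has not yet been measured. It differs from compound 1 by cyclohexyl in place of 2-methoxyphenoxy on an aromatic carbon. Within the data shown here, the only measured step at this place, no change at the digits printed from compound 1 to compound 3 (within the scatter), kept the oxygen link and the aromatic ring and changed nothing; compound 4 loses both, a larger change than that step covers. Compound 2, which carries neither 2-methoxyphenoxy nor a related oxygen-linked aryl group, sits lower, so a moderate drop is expected. Compound 4 is estimated at 7000 nM, with a likely range from 2500 nM to 20000 nM, an expected step of a 2.1-fold lower number from compound 1 to compound 4 (0.32 log units; beyond the scatter).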

Compound 4, solubility: 4200 nM
The estimate for compound 4 lay 1.7-fold (0.22 log units) above the measured number, within the range that was stated.
By their numbers in this assay, from the lowest: compounds 2 and 4 (each within the scatter of the next); then compounds 1 and 3 (each within the scatter of the next).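

In this assay the change to cyclohexyl in place of 2-methoxyphenoxy on an aromatic carbon gives a 3.5-fold lower number from compound 1 to compound 4 (0.54 log units; beyond the scatter) and so shows that this position does not tolerate every substitution equally. The earlier step, no change at the digits printed from compound 1 to compound 3 (within the scatter), exchanged one aryl group on the oxygen for another, whereas this one removes the linking oxygen and the aromatic ring together, and the number moves beyond the scatter. No measurement shown explains the drop.

Which of the two losses matters remains open, and a phenyl group attached directly to that carbon or a cyclohexyloxy group, which keeps the oxygen on a non-aromatic ring, would begin to separate them. Going by these compounds, how an amine or a carboxylic acid at this place would affect the number also remains open.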